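Replacing the aryl group of compound 3

The source may report more compounds than this note shows. Statements on the series, on what has been measured and on what is new or still open speak of the compounds shown alone.

Within the data shown here, in a functional assay on MCF7 cells (Homo sapiens) for cytotoxicity, read by MTT assay, with a stated time of 24 h (on this read-out lower numbers stand for stronger inhibition and higher numbers for weaker inhibition), compound 3 `CCNc1cc(-c2ccc(NC(=O)Nc3ccc(C(F)(F)F)cc3)cc2OC)ccn1` gives 19500 nM, the highest number so far, and its gaps to compound 1 `CCNc1cc(-c2ccc(NC(=O)Nc3c(C)cccc3C)cc2C)ccn1` and compound 2 `CCNc1cc(-c2ccc(NC(=O)Nc3c(C)cccc3C)cc2C(F)(F)F)ccn1` both lie beyond the scatter. Compound 4 `CCNc1cc(-c2ccc(NC(=O)Nc3c(C)cccc3C)cc2OC)ccn1` remains unmeasured and differs from compound 3 as follows: 2,6-dimethylphenyl in place of 4-(trifluoromethyl)phenyl on an amide-type nitrogen.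

Among the measured compounds shown here, no measured step tests this exchange directly. The only one available, a 1.1-fold lower number from compound 1 to compound 2 (0.06 log units; within the scatter), is trifluoromethyl in place of methyl on an aromatic carbon and stays within the scatter. The closest evidence is indirect: compound 1 gives 7920 nM and compound 2 gives 6950 nM, and both carry the entering 2,6-dimethylphenyl, although they also differ from compound 3 elsewhere. A move to a lower number, beyond the scatter, is therefore expected, on only these three values. The estimated step is a 2.4-fold lower number from compound 3 to compound 4 (0.39 log units; beyond the scatter). For compound 4 the estimated value is 8000 nM, with an expected range of 4000 nM to 16000 nM.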

Compound 4, half-maximal inhibitory concentration: 9260 nM
Beside the measured number, compound 4's estimate is 1.2-fold (0.06 log units) below it; low and high end bracket the measured number.
By their numbers in this assay, from the lowest: compounds 2, 1 and 4 (each within the scatter of the next); then compound 3.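

The exchange of 4-(trifluoromethyl)phenyl for 2,6-dimethylphenyl on an amide-type nitrogen now has a direct measure in this assay: a 2.1-fold lower number from compound 3 to compound 4 (0.32 log units; beyond the scatter), a modest step that lies beyond the scatter. With 2,6-dimethylphenyl held fixed, the substituent on the aromatic carbon shows no separation, since methoxy gives a 1.3-fold higher number from compound 2 to compound 4 (0.12 log units; within the scatter) against trifluoromethyl and a 1.2-fold higher number from compound 1 to compound 4 (0.07 log units; within the scatter) against methyl, so among these compounds the high number goes with the 4-(trifluoromethyl)phenyl of compound 3 and not with methoxy. No measured property is available to explain this exchange.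

The exchange is shown only with methoxy on the aromatic carbon, so its size with methyl or trifluoromethyl there remains open. Also open, from the compounds shown here alone, is how a 4-methylphenyl or a 4-carboxyphenyl on the amide-type nitrogen would compare.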